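A few compounds are considered here, and "the series" means these few. Any claim that something is new, unique, unknown or untested is made for them only; others in the source may bear on it.

Measured so far in an ADME assay on BJ cells (Homo sapiens) for cytotoxicity, with a stated time of 72 h (a higher number here means that more compound is needed for the effect, a lower number that less compound is needed), as follows
- compound 1 `O=C(Nc1ccc(-c2nc3ccccc3s2)cc1)c1cc([N+](=O)[O-])ccc1Cl` gives > 27000 nM as a limit
- compound 2 `COC(=O)C1CCN(c2cc(Cl)c(C(=O)Nc3cc(-c4nc5ccccc5s4)ccc3OC)cc2[N+](=O)[O-])CC1` gives > 25000 nM as a limit

Among the compounds with values here, compound 1 therefore has no actual number in this assay and stands at a limit, as does the only other measured compound. Within the data shown here, no step between measured compounds is available to size the next change.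

Compound 3 `O=C(Nc1ccc(Cl)cc1)c1cc([N+](=O)[O-])ccc1Cl` differs from compound 1 as counted here chloro in place of 1,3-benzothiazol-2-yl on an aromatic carbon and carries chloro in place of 1,3-benzothiazol-2-yl on an aromatic carbon, para to a large group.

The expectation rests on compound 1 with its limit of > 27000 nM and on nothing more. No shift beyond the usual scatter is expected in this assay and the reading will probably again be a limit. The expected change is a step that the limit leaves unreadable from compound 1 to compound 3 and stays within the scatter. For compound 3 the estimated value is 30000 nM with an expected range from 10000 nM to 60000 nM in this estimate.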

Compound 3, half-maximal effective concentration: > 27000 nM
Compound 3: only a limit was reported; the forecaster's own chance of this, stated with the estimate: 80%; the middle value is on the limit's open side.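

Compound 1 and compound 3 both stand only at limits in this assay, and the step between them cannot be read. The compounds shown leave open at what concentration any of them reaches the half-maximal effect, and whether chloro in place of 1,3-benzothiazol-2-yl on an aromatic carbon shifts that concentration at all.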